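The source may hold more compounds than are shown below. What is called first, only, known or untested is meant among the compounds shown, and "the series" means these compounds.

Of the compounds shown here, three built on a shared core have been measured in a functional assay on HeLa cells (Homo sapiens) for inhibition, read by sulforhodamine B assay; on this read-out higher numbers stand for weaker inhibition and lower numbers for stronger inhibition. Compound 1 `Cc1ccc(NC2=CC(=O)c3c(nc4n3[C@H]3OC[C@@H](O)[C@H]3OC4)C2=O)cc1C` gives 4320 nM in this assay. Compound 2 `COc1ccc(NC2=CC(=O)c3nc4n(c3C2=O)[C@H]2OC[C@@H](O)[C@H]2OC4)cc1` gives 4780 nM, and compound 3 `Cc1ccc(NC2=CC(=O)c3nc4n(c3C2=O)[C@H]2OC[C@@H](O)[C@H]2OC4)cc1C` gives 2690 nM. Compound 1 thus stands second highest of the three numbers, within the scatter of both compound 2 and compound 3. Among the compounds with values here, the one step between compounds that differ in a single place, a 1.8-fold lower number from compound 2 to compound 3 (0.25 log units; within the scatter), swaps one aryl group on the amine nitrogen for another without moving the number beyond the scatter.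

Compound 4 `O=C1C(Nc2cccc(Cl)c2)=CC(=O)c2c1nc1n2[C@H]2OC[C@@H](O)[C@H]2OC1` differs from compound 1 in one place: 3-chlorophenyl in place of 3,4-dimethylphenyl on an amine nitrogen. Within the data shown here, the only measured step that bears on this change is the aryl exchange from compound 2 to compound 3, which stayed within the scatter, and nothing measured here separates a 3-chlorophenyl from a 3,4-dimethylphenyl. Compound 4 is therefore expected to give about 4000 nM in this assay, with a range of 1500 nM to 11000 nM. For compound 4 the expected step is thus a 1.1-fold lower number from compound 1 to compound 4 (0.03 log units; within the scatter), nothing beyond the scatter.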

Compound 4, half-maximal inhibitory concentration: 7970 nM
The estimate for compound 4 lay 2.0-fold (0.30 log units) below the measured number, within the range that was stated.
By their numbers in this assay, from the lowest: compounds 3, 1, 2 and 4 (each within the scatter of the next, the first and the last beyond it).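

In this assay, putting 3-chlorophenyl in place of 3,4-dimethylphenyl on the amine nitrogen gives a 1.8-fold higher number from compound 1 to compound 4 (0.27 log units; within the scatter) and so stays within the scatter, even though a chlorine now stands where the compound 1 side group carried two methyl carbons. This is the only exchange shown on the core of compound 1, and like a 1.8-fold lower number from compound 2 to compound 3 (0.25 log units; within the scatter) it leaves the number within the scatter, so neither of the two aryl exchanges shown separates its pair of compounds. No measurement given here offers an explanation for this result. Still open, going by these compounds, is whether a group of another kind on this amine nitrogen, such as a benzyl group, a pyridine ring or a longer alkyl chain, would move the number beyond the scatter. Unsubstituted phenyl also remains open as a reference for the substituted rings.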